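Replacing Imidazolylmethyl with a Non-Aromatic Ring: Expected Stability

A few compounds are considered here, and "the series" means these few. Any claim that something is new, unique, unknown or untested is made for them only; others in the source may bear on it.

Measured so far in an ADME assay on microsomes from liver (Rattus norvegicus) for metabolic stability; a lower number here means that the compound disappears faster, a higher number that the compound lasts longer:
compound 1 `CC(C)C(c1nnc[nH]1)c1ccc(-c2ccc3cccc(F)c3c2)[nH]c1=O` gives 0.552 h
compound 2 `CC(C)C(Cc1ncc[nH]1)c1ccc(-c2ccc3cccc(F)c3c2)[nH]c1=O` gives < 0.0667 h
compound 3 `CC(C)[C@H](C[C@H]1CCNC1=O)c1ccc(-c2ccc3cccc(F)c3c2)[nH]c1=O` gives 0.227 h

Compound 2 stands at the bottom of this set; its result is a limit of the assay, not a number (the limit of < 0.0667 h in this assay, at which 1 of the 3 values shown sits). Going by the values given here, only one measured step bears on it directly: the change to (1H-imidazol-2-yl)methyl from 4H-1,2,4-triazol-3-yl on a saturated chain carbon bound to an aromatic carbon and a saturated chain carbon, where an at least 8.2-fold lower number from compound 1 to compound 2 (0.91 log units; beyond the scatter). Compound 3, which carries a non-aromatic ring on the same core, gives a number well clear of the limit in this assay.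

Compound 4 `CC(C)C(/C=C1/CCNC1=O)c1ccc(-c2ccc3cccc(F)c3c2)[nH]c1=O` is not yet measured. It differs from compound 2 at one place: a group of 7 heavy atoms (5 carbon, 1 nitrogen, 1 oxygen; one five-membered non-aromatic ring with 1 hetero atom) in place of a group of 6 heavy atoms (4 carbon, 2 nitrogen; one five-membered aromatic ring with 2 hetero atoms), on a saturated chain carbon bound to an aromatic carbon and a saturated chain carbon. Among the compounds with values here, since the only measured compound that leaves an aromatic ring in this place, compound 3, sits at 0.227 h in this assay, the expectation is that compound 4 also gives a measurable number in this assay, though where it lands is uncertain. The step that this expectation means is an at least 2.9-fold higher number from compound 2 to compound 4 (0.47 log units; beyond the scatter). Compound 4 is thus estimated at 0.2 h in this assay, within a range from 0.07 h to 0.6 h.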

Compound 4, half-life: 0.06 h
For compound 4 the middle estimate is 3.3-fold (0.52 log units) above the measured one; measured number outside the range, below it.
By their numbers in this assay, from the lowest: compound 4; then compound 3; then compound 1.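

Carrying a non-aromatic ring on a saturated chain carbon bound to an aromatic carbon and a saturated chain carbon does not by itself give a compound that lasts in this assay: compound 3 gives 0.227 h, but compound 4, with its own five-membered non-aromatic ring, gives 0.06 h. Set against the 4H-1,2,4-triazol-3-yl group, the new ring comes with a 9.2-fold lower number from compound 1 to compound 4 (0.96 log units; beyond the scatter), so the triazole is not matched by this replacement. How compound 4 compares with compound 2 cannot be read, because the result for compound 2 is a limit of the assay and not a number: the limit of < 0.0667 h in this assay, at which 1 of the 4 values shown sits.

No pair among the compounds shown separates the two double bonds outside aromatic rings in compound 4 from the rest of its group, so what sets compound 4 apart from compound 3 stays open. Also open, on these data alone, is how a simple amine or a carboxylic acid on the same chain carbon would fare in this assay compared with the 4H-1,2,4-triazol-3-yl group.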